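Dropping the 4,6-dimethylpyrimidin-2-yl group from compound 1

The source may hold more compounds than are shown below. What is called first, only, known or untested is meant among the compounds shown, and "the series" means these compounds.

Of the compounds shown here, two have been measured so far in a functional assay on UO-31 cells (Homo sapiens) for antiproliferative activity, read by sulforhodamine B assay, with a stated time of 72 h; a higher number here means a weaker inhibitor, a lower number a stronger inhibitor. Compound 1 `Cc1cc(C)nc(NS(=O)(=O)c2ccc(Nc3nncc4ccccc34)cc2)n1` gives 3.4 nM, the lower of the two numbers. Compound 2 `COc1ccc(NC(=S)NNc2nncc3ccccc23)cc1` gives 47 nM, and the gap between them lies beyond the usual scatter. Compound 1 is therefore the stronger inhibitor of this pair, although the two structures differ in more than one place.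

The next compound to be tested is compound 3 `NS(=O)(=O)c1ccc(Nc2nncc3ccccc23)cc1`. It differs from compound 1 by a single change: hydrogen in place of 4,6-dimethylpyrimidin-2-yl on a sulfonamide nitrogen. Within the data shown here, no measured pair isolates this change, so the expectation rests on judgement rather than on a precedent. Compound 1 sits at 3.4 nM, the low end of the numbers seen so far, and the change removes a whole substituent, which leaves more room for a rise than for a fall. The expected step is a 10-fold higher number from compound 1 to compound 3 (1.01 log units; beyond the scatter), towards a weaker inhibitor and beyond the scatter. Compound 3 is expected at 35 nM, with an estimated range of 6 nM to 250 nM.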

Compound 3, half-maximal inhibitory concentration: 23 nM
Compound 3: middle estimate off by 1.5-fold (0.18 log units), on the high side; the range from low to high includes it.
By their numbers in this assay, from the lowest: compound 1; then compound 3; then compound 2.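

Working from this assay, compound 1 and compound 3 form the first pair in the series that differs in one place, and the change gives a 6.8-fold higher number from compound 1 to compound 3 (0.83 log units; beyond the scatter). The 4,6-dimethylpyrimidin-2-yl group on the sulfonamide nitrogen therefore contributes to the stronger inhibition of compound 1, which the earlier pair, differing in more than one place, could not show, yet the group is not essential, as compound 3 with hydrogen on that nitrogen still gives 23 nM in this assay. No measurement at hand accounts for the size of this step.

Still open, on these data alone, is which part of the departed group carries the effect: an unsubstituted pyrimidin-2-yl, a phenyl or a simple methyl on the same sulfonamide nitrogen would begin to separate the ring, its two methyl groups and its two nitrogens. Also open, as far as these compounds go, is how far the result depends on the sulfonamide itself, a question that a carboxylic acid or a carboxamide in its place would address.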